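Aryl swap on the triazole nitrogen in the spiro series

The source may hold more compounds than are shown below. What is called first, only, known or untested is meant among the compounds shown, and "the series" means these compounds.

Measured so far, all in a functional assay on MCF7 cells (Homo sapiens) for antiproliferative activity, read by MTT assay, with a stated time of 48 h; a higher number here means a weaker inhibitor, a lower number a stronger inhibitor:
- compound 1, `N#CC1=C(N)Oc2c(c3nc4ccccc4nc3c3ccccc23)C12C(=O)N(Cc1cnnn1-c1ccc(Br)cc1)c1ccccc12`: 36600 nM
- compound 2, `CCOc1ccc(-n2nncc2CN2C(=O)C3(C(C#N)=C(N)Oc4c3c3nc5ccccc5nc3c3ccccc43)c3ccccc32)cc1`: a limit, > 50000 nM
- compound 3, `N#CC1=C(N)Oc2c(N)cc3nc4ccccc4nc3c2C12C(=O)N(Cc1cnnn1-c1cccc(C(F)(F)F)c1)c1ccccc12`: 31600 nM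

Compound 2 returns only a limit of the assay, > 50000 nM, so it gives no number (the limit of > 50000 nM in this assay, at which 1 of the 3 values shown sits). Compound 3 holds the lowest of the two numbers shown; its nearest neighbour is compound 1, and the gap between them lies within the scatter, so no order between them is claimed.

Compound 4, `N#CC1=C(N)Oc2c(N)cc3nc4ccccc4nc3c2C12C(=O)N(Cc1cnnn1-c1ccc(Cl)cc1Cl)c1ccccc12`, differs from compound 3 in one place: 2,4-dichlorophenyl in place of 3-(trifluoromethyl)phenyl on an aromatic nitrogen

For the measured compounds named here, the single measured step, an at least 1.3-fold higher number from compound 1 to compound 2 (0.13 log units; that floor lies within the scatter), changes a substituent on the same kind of aryl group but is itself only a floor within the scatter and concerns a different change, so it does not bear directly on compound 4. Nothing in the data separates these aryl variants beyond the scatter. For compound 4 in this assay the expectation is therefore no shift beyond the scatter, a 1.1-fold lower number from compound 3 to compound 4 (0.02 log units; within the scatter). Compound 4 is estimated at 30000 nM, in the range 15000 nM to 50000 nM.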

Compound 4, half-maximal inhibitory concentration: > 50000 nM
Compound 4 was reported as a limit; the forecaster's own chance of this, stated with the estimate: 25%; middle value at least 1.6-fold (0.22 log units) away from the limit.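

Compound 4 is reported in this assay as a limit, not as a number. On the aromatic nitrogen, 2,4-dichlorophenyl in place of 3-(trifluoromethyl)phenyl gives an at least 1.5-fold higher number from compound 3 to compound 4 (0.19 log units; that floor lies within the scatter), so this step is only a floor and does not separate the two aryl groups. Limits now occur with both cores shown, compound 2 on the core of compound 1 and compound 4 on the core of compound 3: the limit of > 50000 nM in this assay, at which 2 of the 4 values shown sit.

Still open, from the compounds shown here alone, is whether any aryl group on this nitrogen can give a number clearly lower than the values seen so far. Also open, going by these compounds, is how an aryl group carrying an amine or a carboxylic acid, or a plain alkyl chain in place of the aryl group, would read in this assay.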